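The compounds below may be only part of what the source reports. "The series", "measured", "known", "first", "only" and "open" are said of these compounds alone.

Measured compounds: compound 1 `COc1ccc(/C=C/C(=O)c2ccc(OC)c3c2OC(C)(C)C=C3)cc1OCC=C(C)C`, compound 2 `C#CCOc1cc(/C=C/C(=O)c2ccc(OC)c3c2OC(C)(C)C=C3)ccc1OC`, compound 3 `CCC(=O)Oc1cc(/C=C/C(=O)c2ccc(OC)c3c2OC(C)(C)C=C3)ccc1OC`.

In a functional assay on HepG2 cells (Homo sapiens) for cytotoxicity, read by MTT assay (on this read-out higher numbers stand for weaker inhibition and lower numbers for stronger inhibition), compound 1 gives > 10000 nM, which is a limit of the assay rather than a number. Compound 2 gives > 10000 nM, also a limit. Compound 3 gives 90 nM. Compound 1 thus stands at the limit of > 10000 nM in this assay, at which 2 of the 3 values shown sit. Compound 4 `COc1cccc(C(=O)Oc2cc(/C=C/C(=O)c3ccc(OC)c4c3OC(C)(C)C=C4)ccc2OC)c1` differs from compound 1 in one place: (3-methoxyphenyl)carbonyl in place of 3-methylbut-2-en-1-yl on an oxygen on an aromatic ring. Among the measured compounds shown here, two measured steps bear on this, each placing a propanoyl on that same oxygen, and each large: an at least 110-fold lower number from compound 1 to compound 3 (2.04 log units; beyond the scatter) and an at least 110-fold lower number from compound 2 to compound 3 (2.04 log units; beyond the scatter). Since compound 4 likewise places a (3-methoxyphenyl)carbonyl on that oxygen, a large drop is expected, about an at least 40-fold lower number from compound 1 to compound 4 (1.60 log units; beyond the scatter). Compound 4 is therefore estimated at 250 nM, in a range from 50 nM to 3000 nM.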

Compound 4, half-maximal inhibitory concentration: 870 nM
Compound 4: the middle estimate sits 3.5-fold (0.54 log units) below what was measured; the range from low to high includes it.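

In this assay, the drop at this oxygen is not confined to propanoyl: (3-methoxyphenyl)carbonyl also gives an at least 11-fold lower number from compound 1 to compound 4 (1.06 log units; beyond the scatter) and an at least 11-fold lower number from compound 2 to compound 4 (1.06 log units; beyond the scatter). What sits on the carbonyl carbon still matters, with 3-methoxyphenyl in place of ethyl giving a 9.7-fold higher number from compound 3 to compound 4 (0.99 log units; beyond the scatter). Compound 1 and compound 2 each stay at a limit rather than a number: the limit of > 10000 nM in this assay, at which 2 of the 4 values shown sit.

On these data alone, whether a longer chain such as butyl on that carbonyl carbon would stay nearer compound 3 or compound 4 remains open. So does the effect of a plain phenyl or an amine-bearing group there.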